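The source may report more compounds than this note shows. Statements on the series, on what has been measured and on what is new or still open speak of the compounds shown alone.

Working notes on the series. Compound 1 `CCCCCc1cn(C/C=C(/C)CC/C=C(\C)CCC=C(C)C)nn1` gives 7.5 in a physicochemical assay for lipophilicity, measured as octanol-water partition; on this read-out lower numbers stand for lower lipophilicity and higher numbers for higher lipophilicity. Compound 2 `CC(C)=CCC/C(C)=C/CC/C(C)=C\Cn1cc(-c2ccccc2)nn1` gives 6.95 in this assay. Compound 3 `CCCCCc1cn(C/C=C(/C)CCC=C(C)C)nn1` gives 5.45 in this assay and stands lowest of the three measured; the values of compound 3 and compound 2 differ by a gap beyond the scatter, and the gap to compound 1 is wider still. The step of a number 0.55 log units lower from compound 1 to compound 2 (beyond the scatter) goes with phenyl in place of pentyl on an aromatic carbon. The core of compound 3 differs from the core of compound 1 by hydrogen in place of 3-methylbut-2-en-1-yl on a saturated chain carbon bound to a double-bonded chain carbon, the change behind the step of a number 2.05 log units lower from compound 1 to compound 3 (beyond the scatter).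

Compound 4 `CC(C)=CCC/C(C)=C\Cn1cc(-c2ccccc2)nn1` is not yet measured in this assay. It differs from compound 3 by phenyl in place of pentyl on an aromatic carbon. This is the same change as that made from compound 1 to compound 2, and the place is the same word for word, so among the compounds shown the change occurs twice in all. Among the measured compounds shown here, the one measured instance of it, the step of a number 0.55 log units lower from compound 1 to compound 2 (beyond the scatter), is modest yet beyond the scatter, and no other instance is available to test whether the size of the step carries over onto the core of compound 3.

For the measured compounds named here, from compound 3 the expected step is a number 0.55 log units lower from compound 3 to compound 4 (beyond the scatter), resting on the single measured instance a number 0.55 log units lower from compound 1 to compound 2 (beyond the scatter) of the same change. Compound 4 is therefore estimated at 4.9 in this assay. For compound 4 the expected range runs from 4.5 to 5.3, widened somewhat since the change is seen only once.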

Compound 4, partition coefficient: 4.91
Compound 4: middle estimate off by 0.01 log units, on the low side; low and high end bracket the measured number.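

In this assay, phenyl in place of pentyl on an aromatic carbon gives a number 0.54 log units lower from compound 3 to compound 4 (beyond the scatter), nearly the same size as a number 0.55 log units lower from compound 1 to compound 2 (beyond the scatter), and hydrogen in place of 3-methylbut-2-en-1-yl on a saturated chain carbon bound to a double-bonded chain carbon gives a number 2.04 log units lower from compound 2 to compound 4 (beyond the scatter), nearly the same size as a number 2.05 log units lower from compound 1 to compound 3 (beyond the scatter). The phenyl-for-pentyl step thus carries from the core of compound 1 to the core of compound 3 with its size intact, and none of the four compounds goes against this, but the agreement rests on one pair of cores and one pair of groups and does not show that the step would hold on any further core. Nothing at hand explains why the step carries over.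

The compounds shown leave open whether a group of another kind on the same aromatic carbon, such as an amine, a carboxylic acid or a longer chain than pentyl, would also give a step of one size on both cores. They also leave open whether the match would persist on a core with a longer chain in place of 3-methylbut-2-en-1-yl.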